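The compounds below may be only part of what the source reports. "The series", "measured", "known", "first", "only" and "open" are said of these compounds alone.

Compound 1 `COc1ccccc1NC(=S)N/N=C/c1ccc2ccccc2n1` belongs to a small set of thiosemicarbazones built on a shared core and tested in a functional assay on HT-29 cells (Homo sapiens) for antiproliferative activity, read by sulforhodamine B assay, with a stated time of 72 h; on this read-out lower numbers stand for stronger inhibition and higher numbers for weaker inhibition. In this assay compound 1 gives only a limit, > 100000 nM, so its true value is not known as a number. Compound 2 `CN(C)C(=S)N/N=C/c1ccc2ccccc2n1`, which carries a dimethyl group on the thioamide nitrogen in place of an aryl group, gives 20 nM. Compound 3 `FC(F)(F)c1ccccc1NC(=S)N/N=C/c1ccc2ccccc2n1` gives 18100 nM. Among the compounds with values here, the step of an at least 5.5-fold lower number from compound 1 to compound 3 (0.74 log units; beyond the scatter) is the only measured change of the aryl substituent on the same core, and it runs in the direction of a lower number. Its size rests on the value of compound 1, which is only a limit (the limit of > 100000 nM in this assay, at which 1 of the 3 values shown sits).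

Compound 4 `Cc1cccc(NC(=S)N/N=C/c2ccc3ccccc3n2)c1` is the next member of this series, and it differs from compound 1 by 3-methylphenyl in place of 2-methoxyphenyl on an amide-type nitrogen. Within the data shown here, the one measured step that changes the substituent on this aryl ring, from compound 1 to compound 3, lowered the number at least modestly, so a step of a similar kind, toward a lower number, is expected in this assay for compound 4. Compound 4 is therefore estimated at 30000 nM, with a likely range from 8000 nM to 100000 nM, which would correspond to a step of an at least 3.3-fold lower number from compound 1 to compound 4 (0.52 log units; beyond the scatter).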

Compound 4, half-maximal inhibitory concentration: > 100000 nM
Compound 4 was reported as a limit; the forecaster's own chance of this, stated with the estimate: 30%; middle value at least 3.3-fold (0.52 log units) from the limit.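

In this assay compound 4 gives > 100000 nM as a limit of the assay and not a number. Within the data shown here, compound 1 also stands only as a limit, so no step from compound 1 to compound 4 can be read: the limit of > 100000 nM in this assay, at which 2 of the 4 values shown sit. The compounds shown leave open where the true values of compound 1 and compound 4 lie, and so how 3-methylphenyl compares with 2-methoxyphenyl on this nitrogen.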